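The source may hold more compounds than are shown below. What is called first, only, known or untested is meant among the compounds shown, and "the series" means these compounds.

Of the compounds shown here, two have been tested so far in an ADME assay on HEp-2 cells (Homo sapiens) for cytotoxicity, read by CCK-8 assay, with a stated time of 5 days; a lower number here means that less compound is tolerated, a higher number that more compound is tolerated. Compound 1 `CS(=O)(=O)c1ccc2nc(N3CCCc4ccccc4C3)cc(NCCN)c2c1` gives 13000 nM. Compound 2 `Cc1ccc2nc(N3CCCc4ccc(F)cc4C3)cc(NCC(C)(C)N)c2c1` gives 23000 nM in this assay. These two numbers lie within the usual scatter of each other, so the measurements do not separate compound 2 from compound 1 in any meaningful way.

Compound 3 `Cc1ccc2nc(N3CCCc4ccc(F)cc4C3)cc(NCCO)c2c1` has not yet been measured. It differs from compound 2 in one place: hydroxymethyl in place of 1-amino-1-methylethyl on a saturated chain carbon bound to a nitrogen on an aromatic ring. Going by the values given here, no measured pair in this set shows that change, so there is no observed step to lean on. What the two measured compounds do show is that their numbers in this assay sit close together, and nothing in that pair points toward a large move for a change of this kind. The expected step of a 1.2-fold lower number from compound 2 to compound 3 (0.06 log units; within the scatter) is therefore small, with no clear direction beyond the scatter. For compound 3 the estimate is 20000 nM, with a range from 8000 nM to 50000 nM in this assay.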

Compound 3, half-maximal cytotoxic concentration: > 100000 nM
Compound 3 gave a limit, no number; the forecaster's own chance of this, stated with the estimate: 15%; at least 5.0-fold (0.69 log units) between middle value and limit.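

In this assay compound 3 gives > 100000 nM, which is a limit of the assay and not a number. Replacing 1-amino-1-methylethyl with hydroxymethyl on a saturated chain carbon bound to a nitrogen on an aromatic ring gives an at least 4.3-fold higher number from compound 2 to compound 3 (0.63 log units; beyond the scatter), the first readable sign that this side chain can shift how much compound the cells tolerate, something compound 1 and compound 2 could not show, as they differ in more than one place. The true size of this step stays unknown, and the reading rests on a single result at the top of the range: the limit of > 100000 nM in this assay, at which 1 of the 3 values shown sits.

Still open, going by these compounds, is whether the step goes with the oxygen that replaces the nitrogen or with the loss of the methyl groups, as this one change alters both at once, and a 2-hydroxy-2-methylpropyl chain on the same core would pull the two apart. Also open, on these data alone, is whether a longer chain such as 3-hydroxypropyl, or a carboxylic acid at the end of the chain, would behave like the hydroxymethyl group.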